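Phenethyl in place of an arylamino group on a carbonyl

This account rests on a few compounds, and the source may have more. Where it says the series, first, only, none or still open, it means among the compounds named here.

Measured compounds:
compound 1 `COc1ccc(-c2cnc3nc(N)nc(N4CCN(C(=O)Nc5ccc(C)cc5)CC4)c3n2)cc1OC` — 0.8 nM
compound 2 `CCOc1nc(N)nc2ncc(-c3ccc(OC)cc3)nc12` — > 10000 nM

In a functional assay on cells (T-cell, Homo sapiens) for inhibition (on this read-out higher numbers stand for weaker inhibition and lower numbers for stronger inhibition), compound 1 gives 0.8 nM, which is the only numerical value among the two results shown. For compound 2 the result in this assay is not a number but a limit of the assay, > 10000 nM (the limit of > 10000 nM in this assay, at which 1 of the 2 values shown sits). Compound 3 `COc1ccc(-c2cnc3nc(N)nc(N4CCN(C(=O)CCc5ccccc5)CC4)c3n2)cc1OC` has not yet been measured in this assay. It differs from compound 1 in a single place: phenethyl in place of (4-methylphenyl)amino on a carbonyl carbon. Going by the values given here, no step between two measured compounds is available to calibrate a change of this kind, so the expectation rests on compound 1 alone. The expected step from compound 1 to compound 3 is a 6.3-fold higher number from compound 1 to compound 3 (0.80 log units; beyond the scatter), a loss of potency somewhat beyond the usual scatter. Compound 3 is therefore expected to give 5 nM in this assay, with a range from 1 nM to 40 nM.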

Compound 3, half-maximal inhibitory concentration: 100 nM
Compound 3: middle estimate off by 20-fold (1.30 log units), on the low side; measured number outside the range, above it.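

In this assay the carbonyl carbon bonded to the amide-type ring nitrogen proves highly sensitive to this exchange, which gives a 130-fold higher number from compound 1 to compound 3 (2.10 log units; beyond the scatter) and is a large loss of potency. The two groups have the same count of heavy atoms and each holds one six-membered aromatic ring of carbon only, so the step comes with a change in the link to that ring and the loss of the 1 hydrogen-bond donor of (4-methylphenyl)amino, and of its methyl group, while size by heavy-atom count stays the same. Nothing measured here bears on why the step is so large.

The compounds shown leave open whether the linking nitrogen or the methyl group accounts for the loss. A phenylamino group or a 4-methylphenethyl group on the same carbonyl carbon would separate the two.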